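Swapping Trifluoromethyl for Chloro on the Sulfonamide Aryl Ring

The source may report more compounds than this note shows. Statements on the series, on what has been measured and on what is new or still open speak of the compounds shown alone.

Measured compounds:
compound 1 `CCOc1cc(=O)n(CCCO)c2c1CC(CC=C(C)C)C(C)(C)C2`: 66.5%
compound 2 `CC(C)=CCC1Cc2c(OCCCNS(=O)(=O)c3ccc(C(F)(F)F)cc3)cc(=O)n(CCCO)c2CC1(C)C`: 29.6%

In a functional assay on PANC-1 cells (Homo sapiens) for inhibition, read by MTT assay, with a stated time of 24 h, tested at 10 uM (a higher number here means more inhibition at the concentration tested (going by the name of the read-out), a lower number less inhibition), compound 1 gives 66.5%. In this assay compound 2 gives 29.6%, the lowest of the two numbers; the gap to compound 1 lies beyond the usual scatter. The two measured compounds differ from each other in more than one place, so no single-change step can be read from them.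

Compound 3 `CC(C)=CCC1Cc2c(OCCCNS(=O)(=O)c3ccc(Cl)cc3)cc(=O)n(CCCO)c2CC1(C)C` differs from compound 2 in one place only: chloro in place of trifluoromethyl on an aromatic carbon. Among the compounds with values here, with no measured single-change step to lean on, the step from compound 2 is expected to be small, with no clear direction and most likely within the scatter. The step of a number 2.4 percentage points higher from compound 2 to compound 3 (within the scatter) is estimated to stay within that scatter. Compound 3 is expected to give about 32%, with a range from 15% to 50%.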

Compound 3, a percentage reported as inhibition, at one concentration (the size of the read-out at that concentration, not a potency): 24.7%
Compound 3: the middle estimate sits 7.3 percentage points above what was measured, and the stated range covers the measured number.
By their numbers in this assay, from the lowest: compounds 3 and 2 (each within the scatter of the next); then compound 1.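

In this assay, the step from 4-(trifluoromethyl)phenyl to 4-chlorophenyl is a number 4.9 percentage points lower from compound 2 to compound 3 (within the scatter), so these two groups on an aromatic carbon of the ring cannot be told apart by this read-out. The larger change, (((4-chlorophenyl)sulfonyl)amino)methyl in place of hydrogen on a saturated chain carbon, is a number 41.8 percentage points lower from compound 1 to compound 3 (beyond the scatter), and it shows that the low number also holds with chloro on the ring, not only with trifluoromethyl. Nothing measured here explains either step.

Still open, from the compounds shown here alone, is whether a clearly different group on that aromatic carbon, such as an amine or a carboxylic acid, would move the number beyond the scatter. Also open, going by these compounds, is how a longer chain between the oxygen and the sulfonamide nitrogen would read.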